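The source may hold more compounds than are shown below. What is called first, only, known or untested is meant among the compounds shown, and "the series" means these compounds.

Working notes on the series. Among the compounds with values here, compound 1 `CCOC(=O)C1=Cc2ccccc2OC1(OCc1cc(-c2ccc(OC)cc2)no1)C(F)(F)F` is the first member. In a functional assay on A549 cells (Homo sapiens) for inhibition, read by MTT assay, with a stated time of 24 h (on this read-out lower numbers stand for stronger inhibition and higher numbers for weaker inhibition), compound 1 gives > 150000 nM, which is a limit of the assay and not a number. Compound 3 `CCOC(=O)C1=Cc2ccccc2OC1(OCc1cc(-c2ccc(Br)cc2)no1)C(F)(F)F` carries bromo in place of methoxy on an aromatic carbon. In this assay compound 3 gives > 150000 nM, again a limit. The step that the two limits leave unreadable from compound 1 to compound 3 is therefore not readable. Compound 2 `CCOC(=O)C1=Cc2ccccc2OC1(OCc1cn(-c2ccc(C)cc2)nn1)C(F)(F)F` gives 19700 nM in this assay. Compound 3 thus stands at the limit of > 150000 nM in this assay, at which 2 of the 3 values shown sit. Compound 4 `CCOC(=O)C1=Cc2ccccc2OC1(OCc1cc(-c2ccc3ccccc3c2)no1)C(F)(F)F` differs from compound 3 by naphthalen-2-yl in place of 4-bromophenyl on an aromatic carbon. Within the data shown here, no measured step bears on this change, since the single measured step runs between two limits. Compound 4 is expected to stay at a limit, estimated at 150000 nM with a range of 40000 nM to 400000 nM. The expected step is a number no higher from compound 3 to compound 4 (the limit leaves the size open).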

Compound 4, half-maximal inhibitory concentration: > 150000 nM
Compound 4 gave a limit, no number (the forecaster's own chance of this, stated with the estimate: 70%); the middle value sits exactly at the limit.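

Within the data shown here, compound 1, compound 3 and compound 4 all stand at a limit of the assay and not at a number, so no step among them can be read in this assay. The compounds shown leave open how 4-methoxyphenyl, 4-bromophenyl and naphthalen-2-yl compare with one another.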